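Fluoro for methoxy on the aryl ether of compound 2

The compounds below may be only part of what the source reports. "The series", "measured", "known", "first", "only" and "open" are said of these compounds alone.

Measured compounds:
compound 1, `COc1cccc(Oc2ccc3c(NCCCNCc4cccc(OC)c4O)ccnc3c2)c1`, 14500 nM
compound 2, `COc1ccc(Oc2ccc3c(NCCCNCc4cccc(OC)c4O)ccnc3c2)cc1`, 14500 nM

Both compounds were tested in a physicochemical assay for solubility, with a stated time of 18 h, at pH 7.4; on this read-out lower numbers stand for lower solubility and higher numbers for higher solubility. Compound 1 gives 14500 nM in this assay. Compound 2 gives 14500 nM, so the two stand level at the digits shown. Among the measured compounds shown here, the one measured step, no change at the digits printed from compound 1 to compound 2 (within the scatter), moves the methoxy group round the aryl ether and leaves the read-out unchanged within the scatter.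

Compound 3, `COc1cccc(CNCCCNc2ccnc3cc(Oc4ccc(F)cc4)ccc23)c1O`, has not yet been measured in this assay. It differs from compound 2 by fluoro in place of methoxy on an aromatic carbon. For the measured compounds named here, no measured pair here shows a methoxy-to-fluoro exchange, so the step from compound 1 to compound 2 bears on it only indirectly: it shows that a small change on this ring left solubility where it was. On that basis the account expects little or no movement beyond the scatter for compound 3, a step of about a 1.2-fold lower number from compound 2 to compound 3 (0.08 log units; within the scatter). The estimate for compound 3 in this assay is therefore 12000 nM, with a range from 5000 nM to 30000 nM.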

Compound 3, solubility: 14500 nM
Estimate against measurement, compound 3: 1.2-fold (0.08 log units) below; the range from low to high includes it.
By their numbers in this assay, from the lowest: compounds 1, 2 and 3 (each within the scatter of the next).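

In this assay, among the compounds shown here, the first exchange of the substituent itself at this place, on an aromatic carbon para to a large group, gives no change at the digits printed from compound 2 to compound 3 (within the scatter) and thus takes the 4-methoxyphenoxy group to the 4-fluorophenoxy group with the read-out staying level. The earlier pair had shown only that methoxy could be moved on this ring; the new result shows that methoxy can also be replaced by fluoro, with one heavy atom in place of two and one hydrogen-bond acceptor fewer counted on the group, and the value holds. Taken across both changes at once, the comparison gives no change at the digits printed from compound 1 to compound 3 (within the scatter) and so the three aryl ethers stand together, while no measurement at hand explains why the read-out stays level.

Going by these compounds, only methoxy and fluoro have been seen on this ring, so it remains open whether an amine or a carboxylic acid at the same place would move the read-out beyond the scatter. The rest of the molecule is the same in all three compounds, which leaves the effect of any change outside the aryl ether unknown.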